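Aryl exchange at the weak end of the series

A few compounds are considered here, and "the series" means these few. Any claim that something is new, unique, unknown or untested is made for them only; others in the source may bear on it.

In a functional assay on PC-3 cells (Homo sapiens) for antiproliferative activity, read by MTT assay, with a stated time of 72 h (a lower number here means a stronger inhibitor, a higher number a weaker inhibitor), compound 1 `O=C(N/N=C/c1ccc(Br)cc1)Nc1ccc(Oc2ccnc3[nH]ccc23)c(F)c1` gives 920 nM, compound 2 `N#Cc1ccc(/C=N/NC(=O)Nc2ccc(Oc3ccnc4[nH]ccc34)c(F)c2)cc1` gives 9030 nM and compound 3 `O=C(N/N=C/c1ccc(Cl)c(Cl)c1)Nc1ccc(Oc2ccnc3[nH]ccc23)c(F)c1` gives 14100 nM. Compound 3 thus sits with compound 2 at the weak end: a 1.6-fold higher number from compound 2 to compound 3 (0.19 log units; within the scatter) stays within the scatter, while a 15-fold higher number from compound 1 to compound 3 (1.19 log units; beyond the scatter) and a 9.8-fold higher number from compound 1 to compound 2 (0.99 log units; beyond the scatter) go beyond it. Compound 4 `O=C(N/N=C/c1ccc(O)cc1O)Nc1ccc(Oc2ccnc3[nH]ccc23)c(F)c1` has 2,4-dihydroxyphenyl in place of 3,4-dichlorophenyl on a carbon with a double bond to nitrogen. Among the compounds with values here, the three measured steps show that changes on this aromatic ring can move the number widely, but none of the measured compounds carries 2,4-dihydroxyphenyl, so they give size rather than direction. Compound 3 already has a number as high as any seen here, so a modest move towards lower numbers in this assay is expected, with wide uncertainty. The estimated step is a 2.4-fold lower number from compound 3 to compound 4 (0.37 log units; beyond the scatter). For compound 4 the expected value is 6000 nM, with an estimated range of 1300 nM to 25000 nM.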

Compound 4, half-maximal inhibitory concentration: 13000 nM
The estimate for compound 4 lay 2.2-fold (0.34 log units) below the measured number, and the stated range covers the measured number.
By their numbers in this assay, from the lowest: compound 1; then compounds 2, 4 and 3 (each within the scatter of the next).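

In this assay, 2,4-dihydroxyphenyl on a carbon with a double bond to nitrogen joins the weak end of the series: a 1.1-fold lower number from compound 3 to compound 4 (0.04 log units; within the scatter) and a 1.4-fold higher number from compound 2 to compound 4 (0.16 log units; within the scatter) stay within the scatter, while a 14-fold higher number from compound 1 to compound 4 (1.15 log units; beyond the scatter) goes beyond it. A ring carrying hydrogen-bond donors and acceptors thus reads the same, within the scatter, as the 3,4-dichlorophenyl ring, which has none, so the count of these groups does not separate compounds 2, 3 and 4, and only compound 1 with its 4-bromophenyl stands apart. No measured evidence on these rings bears on this result.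

On these data alone, whether compound 1 is a lone exception remains open. A plain phenyl, 4-chlorophenyl or 4-aminophenyl ring at this place would show whether the low number belongs to bromo alone.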